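Larger hydroxylated aryl group on the shared core

A few compounds are considered here, and "the series" means these few. Any claim that something is new, unique, unknown or untested is made for them only; others in the source may bear on it.

Compound 1 `COc1cc(N2C(N)=C(C#N)C(c3ccc([N+](=O)[O-])cc3)C3=C2CC(C)(C)CC3=O)cc(OC)c1OC` was tested in a functional assay on Ehrlich cells (Mus musculus) for cytotoxicity, tested at 50 ug/mL (a lower number here means a weaker effect, a higher number a stronger effect of the compound at the concentration tested), where compound 1 gives 70%. Among the compounds with values here, this is the highest of the three numbers measured so far. Compound 2 `COc1cc(N2C(N)=C(C#N)C(/C=C/c3ccccc3)C3=C2CC(C)(C)CC3=O)cc(OC)c1OC` gives 30% in this assay, and compound 3 `COc1cc(N2C(N)=C(C#N)C(c3ccccc3O)C3=C2CC(C)(C)CC3=O)cc(OC)c1OC` gives 2%. Both steps away from compound 1 lie beyond the scatter: a number 40 percentage points lower from compound 1 to compound 2 (beyond the scatter), and a number 68 percentage points lower from compound 1 to compound 3 (beyond the scatter). Between the two weaker compounds, a number 28 percentage points lower from compound 2 to compound 3 (beyond the scatter).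

Compound 4 `COc1cc(N2C(N)=C(C#N)C(c3c(O)ccc4ccccc34)C3=C2CC(C)(C)CC3=O)cc(OC)c1OC` has not yet been measured. It differs from compound 1 in one place: 2-hydroxynaphthalen-1-yl in place of 4-nitrophenyl on a saturated ring carbon. The measured step most like this change is a number 68 percentage points lower from compound 1 to compound 3 (beyond the scatter), which came with 2-hydroxyphenyl in place of 4-nitrophenyl; the entering 2-hydroxynaphthalen-1-yl likewise carries one hydrogen-bond donor and one acceptor in place of the two acceptors of 4-nitrophenyl. The other step from compound 1, a number 40 percentage points lower from compound 1 to compound 2 (beyond the scatter), also went downward, so no replacement of 4-nitrophenyl seen so far has held the activity. A large drop is therefore expected in this assay. Compound 4 is estimated at 15%, with a range from 0% to 45%. The expected step is a number 55 percentage points lower from compound 1 to compound 4 (beyond the scatter).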

Compound 4, a percentage reported as activity, at one concentration (the size of the read-out at that concentration, not a potency): 15%
The estimate for compound 4 equals the measured number at the digits printed; low and high end bracket the measured number.
By their numbers in this assay, from the lowest: compound 3; then compound 4; then compound 2; then compound 1.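

In this assay, the second aromatic ring of 2-hydroxynaphthalen-1-yl gives a measurable gain over the single ring of 2-hydroxyphenyl, with a number 13 percentage points higher from compound 3 to compound 4 (beyond the scatter). That gain recovers only part of what is lost on leaving 4-nitrophenyl, with a number 55 percentage points lower from compound 1 to compound 4 (beyond the scatter), and it still does not reach the level of the 2-phenylethenyl group, with a number 15 percentage points lower from compound 2 to compound 4 (beyond the scatter). So this position responds to the size of the aryl group even when the hydroxyl is kept, yet all three replacements tried so far remain lower than 4-nitrophenyl, and nothing available explains why these groups rank in this order.

The compounds shown leave open whether the lower numbers go with the added hydroxyl or with the loss of the nitro group, a question that an unsubstituted phenyl or naphthalen-1-yl group at this carbon could help to settle. They also leave open whether the nitro group itself is needed, or whether another group in its place on the phenyl ring, such as an amine or a carboxylic acid, would hold the activity of compound 1.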